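Sec-butyl in place of ethoxyethyl on the carbamoyl nitrogen

This account rests on a few compounds, and the source may have more. Where it says the series, first, only, none or still open, it means among the compounds named here.

This account follows two acid ceramidase inhibitors sharing one core and adds a third. In an assay on HEK293 cells for inhibition of acid ceramidase (Homo sapiens), read by fluorescence, with stated times of 10 min and 3 h (a higher number here means a weaker inhibitor, a lower number a stronger inhibitor), compound 1 `CN1CCC(c2ccc3c(c2)oc(=O)n3C(=O)NCCCCc2ccc(F)cc2)CC1` gives 94 nM. In this assay compound 2 `CCOCCNC(=O)n1c(=O)oc2cc(C3CCN(C)CC3)ccc21` gives 1050 nM, the highest of the two numbers, and the step of an 11-fold higher number from compound 1 to compound 2 (1.05 log units; beyond the scatter) is the only measured one here. Compound 3 `CCC(C)NC(=O)n1c(=O)oc2cc(C3CCN(C)CC3)ccc21` is not yet measured. It differs from compound 2 in one place: sec-butyl in place of 2-ethoxyethyl on an amide-type nitrogen. Among the compounds with values here, no measured step covers this exact exchange. Within the data shown here, the one step that bears on the same nitrogen, an 11-fold higher number from compound 1 to compound 2 (1.05 log units; beyond the scatter), shows that this position can move the number a lot, but there a long aryl-bearing chain was exchanged for a short one, whereas here one short chain is exchanged for another of similar length, so a smaller movement than that step is expected. The exchange of compound 2 to compound 3 is estimated to yield a 1.2-fold lower number from compound 2 to compound 3 (0.07 log units; within the scatter), leaning toward no change beyond the scatter. Compound 3 is therefore expected to give 900 nM, with a range from 300 nM to 3000 nM.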

Compound 3, half-maximal inhibitory concentration: 2100 nM
The estimate for compound 3 lay 2.3-fold (0.37 log units) below the measured number, within the range that was stated.
By their numbers in this assay, from the lowest: compound 1; then compounds 2 and 3 (each within the scatter of the next).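

In this assay the exchange of 2-ethoxyethyl for sec-butyl on the amide-type nitrogen gives a 2.0-fold higher number from compound 2 to compound 3 (0.30 log units; within the scatter) and so does not separate the two compounds. Within the data shown here, this is the first sign that this position can take a change of short chain, including the loss of the hydrogen-bond acceptor counted in 2-ethoxyethyl, without a shift beyond the scatter, in contrast to the large step of an 11-fold higher number from compound 1 to compound 2 (1.05 log units; beyond the scatter) that came with the exchange of the chain carrying 2-(4-fluorophenyl)ethyl. Nothing measured here explains why the two short chains sit so close together.

The compounds shown leave open whether the lower number of compound 1 depends on the 4-fluorophenyl group or on the length of its chain, a question that a plain hexyl chain and a chain ending in unsubstituted phenyl would help to separate. They also leave open how this nitrogen would respond to a short chain ending in an amine or a carboxylic acid, or to a small ring such as cyclobutyl in place of sec-butyl.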